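Compound 2 to compound 4: nitro in place of amino

The source may hold more compounds than are shown below. What is called first, only, known or untested is meant among the compounds shown, and "the series" means these compounds.

Measured so far in a toxicity assay on NIH3T3 cells (Mus musculus) for cytotoxicity, read by resazurin assay (on this read-out lower numbers stand for an effect already at smaller amounts and higher numbers for an effect only at larger amounts of compound), are these three:
Compound 1 `CNC(=O)c1ccc(NCc2cncn2Cc2ccc(-c3ccccc3)cc2N)cc1-c1ccccc1` gives > 1000 nM as a limit
Compound 2 `COC(=O)c1ccc(NCc2cncn2Cc2ccc(N)cc2)cc1-c1ccccc1` gives > 10000 nM as a limit
Compound 3 `O=C(c1ccc(NCc2cncn2Cc2ccc(-c3ccccc3)cc2)cc1-c1ccccc1)N1CCCCC1` gives > 1000 nM as a limit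

None of the three has a number, only a limit. Compound 2 stands at the limit of > 10000 nM in this assay, at which 1 of the 3 values shown sits, and so holds a limit of its own, with no exact value known. The change to compound 4 `COC(=O)c1ccc(NCc2cncn2Cc2ccc([N+](=O)[O-])cc2)cc1-c1ccccc1` is nitro in place of amino on an aromatic carbon and puts nitro in place of amino on an aromatic carbon. Within the data shown here, no measured pair shows this change, so the expectation rests only on the limit that compound 2 gives, > 10000 nM and nothing more. The expected change is a step that the limit leaves unreadable from compound 2 to compound 4 in this assay and thus none beyond the scatter, with no direction favoured. For compound 4 the estimate is 12000 nM within an expected range of 4000 nM to 30000 nM and the read-out may well be only a limit again.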

Compound 4, half-maximal effective concentration: > 10000 nM
Compound 4: no number, only a limit (the forecaster's own chance of this, stated with the estimate: 75%); the middle value is on the limit's open side.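

In this assay compound 4 gives > 10000 nM, which is a limit. Among these compounds, compound 2 also holds only a limit, so no step between compound 2 and compound 4 can be read. The compounds shown leave open how nitro and amino compare in this assay, with no exact value among them.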